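Swapping the amine-linked acid side chain on the core

The source may hold more compounds than are shown below. What is called first, only, known or untested is meant among the compounds shown, and "the series" means these compounds.

Compound 2 `CN(Cc1ccc(C(=O)O)cc1)c1ccc(OCc2c(-c3c(Cl)cccc3Cl)noc2C2CC2)nc1C(F)(F)F`: 81%
Compound 3 `CN(Cc1ccc(C(=O)NCCS(=O)(=O)O)cc1)c1ccc(OCc2c(-c3c(Cl)cccc3Cl)noc2C2CC2)nc1C(F)(F)F`: 57%
Compound 1 `CC(C)c1onc(-c2c(Cl)cccc2Cl)c1COc1ccc(N(C)Cc2ccc(CCC(=O)O)cc2)c(C(F)(F)F)n1`: 55%

In a functional assay on HEK293 cells for agonist activity at Bile acid receptor (Homo sapiens) (on this read-out lower numbers stand for smaller maximal responses and higher numbers for larger maximal responses), compound 2 gives 81%, the highest of the three numbers; compound 3 and compound 1 both lie beyond the scatter below it. Going by the values given here, the one measured single-point step, a number 24 percentage points lower from compound 2 to compound 3 (beyond the scatter), concerns the carboxylic acid end and not the side chain linker. Compound 1 differs from compound 2 in more than one place, so only its value can be read.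

Compound 4 `CC(Oc1ccc(C(=O)O)cc1)c1ccc(OCc2c(-c3c(Cl)cccc3Cl)noc2C2CC2)nc1C(F)(F)F` keeps the carboxylic acid and changes the link between the core and the acid-bearing ring: 1-(4-carboxyphenoxy)ethyl in place of (4-carboxybenzyl)(methyl)amino on an aromatic carbon. Among the compounds with values here, no measured step touches this part of the molecule, so the direction of the change is unknown and the estimate is wide. Within the data shown here, a modest loss is expected, a number 16 percentage points lower from compound 2 to compound 4 (beyond the scatter), mostly because the only change tried from compound 2 so far, a number 24 percentage points lower from compound 2 to compound 3 (beyond the scatter), lowered the response. Compound 4 is therefore estimated at 65%, in a range from 35% to 95%.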

Compound 4, largest response reached (reported as efficacy), in percent of the reference or control that the assay uses: 70%
Beside the measured number, compound 4's estimate is 5 percentage points below it; low and high end bracket the measured number.
By their numbers in this assay, from the lowest: compounds 1 and 3 (each within the scatter of the next); then compound 4; then compound 2.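

The link between the core and the acid-bearing ring, on the aromatic carbon ortho to a trifluoromethyl group, now has a measured step of its own: in this assay this swap gives a number 11 percentage points lower from compound 2 to compound 4 (beyond the scatter) while the carboxylic acid stays in place. The leaving and entering groups match in heavy-atom, hydrogen-bond donor and hydrogen-bond acceptor counts, and the entering group has oxygen in place of the nitrogen, so a change this small on those counts still shifts the maximal response. The response is lowered but not lost, with compound 4 still reaching 70%, so the (4-carboxybenzyl)(methyl)amino group is not the only one at this position that gives a clear response.

Going by these compounds, whether an amide link, or an ether link without the branching methyl, would restore the response remains open. Nothing available here explains the lower response.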